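A few compounds are considered here, and "the series" means these few. Any claim that something is new, unique, unknown or untested is made for them only; others in the source may bear on it.

Measured in a functional assay on MGC-803 cells (Homo sapiens) for cytotoxicity, read by MTT assay, with a stated time of 72 h; a higher number here means a weaker inhibitor, a lower number a stronger inhibitor:
- compound 1 `COc1cc(C=C2C(=O)N(c3ccc(Cl)cc3)N(c3ccc(Cl)cc3)C2=O)ccc1O`: 21800 nM
- compound 2 `O=C1C(=Cc2ccc(F)cc2F)C(=O)N(c2ccc(Cl)cc2)N1c1ccc(Cl)cc1`: 35700 nM

Among the compounds with values here, the only measured step is a 1.6-fold higher number from compound 1 to compound 2 (0.21 log units; within the scatter). Compound 2 therefore cannot be separated from the other measured compound, and both sit in the same range on these numbers.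

Next in the series is compound 3 `O=C1C(=C/C=C/c2ccccc2)C(=O)N(c2ccc(Cl)cc2)N1c1ccc(Cl)cc1`. The change from compound 2 is 2-phenylethenyl in place of 2,4-difluorophenyl on a double-bonded chain carbon bound to a double-bonded ring carbon. It falls at the same place as the measured step: on a double-bonded chain carbon bound to a double-bonded ring carbon. Within the data shown here, that step exchanged 4-hydroxy-3-methoxyphenyl for 2,4-difluorophenyl and stayed within the scatter, so it is the only guide here. Among the measured compounds shown here, it is thin evidence, as no measured compound carries a 2-phenylethenyl group.

No step beyond the scatter is expected in this assay, and the data support no firm direction. The expected change is a 1.2-fold lower number from compound 2 to compound 3 (0.08 log units; within the scatter). For compound 3 the estimated value is 30000 nM, with an expected range of 12000 nM to 70000 nM.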

Compound 3, half-maximal inhibitory concentration: 5100 nM
Estimate against measurement, compound 3: 5.9-fold (0.77 log units) above; the whole stated range lies above it.
By their numbers in this assay, from the lowest: compound 3; then compounds 1 and 2 (each within the scatter of the next).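

In this assay the position on a double-bonded chain carbon bound to a double-bonded ring carbon now shows steps beyond the scatter: 2-phenylethenyl in place of 2,4-difluorophenyl gives a 7.0-fold lower number from compound 2 to compound 3 (0.85 log units; beyond the scatter) and 2-phenylethenyl in place of 4-hydroxy-3-methoxyphenyl gives a 4.3-fold lower number from compound 1 to compound 3 (0.63 log units; beyond the scatter). The position is therefore not indifferent to the group it carries, which the earlier exchange, lying within the scatter, could not show, and both modest steps run in the same direction whichever of the two earlier groups leaves. Against 2,4-difluorophenyl the heavy atom count stays at 8 and one six-membered aromatic ring remains, so the exchange swaps the fluorine atoms for carbon and adds 1 double bond outside aromatic rings, though nothing at hand gives a reason for the lower number.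

The compounds shown leave open whether the lower number goes with the double bond in the chain or with the ring lacking fluorine, hydroxy and methoxy groups. A plain phenyl at this position, a longer chain with a further double bond, or a 2-phenylethenyl group carrying an amine on its ring would begin to separate these readings.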